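The compounds below may be only part of what the source reports. "The series", "measured", "known", "first", "only" and "open" are said of these compounds alone.

Working notes on the series. Compound 1 `ClCc1ccc(Cn2cnc3c(Cl)ncnc32)cc1` is recorded as "not determined" (no result reported) in a functional assay on SW-620 cells (Homo sapiens) for cytotoxicity, read by sulforhodamine B assay, with a stated time of 48 h (on this read-out higher numbers stand for weaker inhibition of growth and lower numbers for stronger inhibition of growth), and so stands without a number. Its isomer compound 2 `ClCc1ccccc1Cn1cnc2c(Cl)ncnc21` gives 5010 nM in this assay. Within the data shown here, compound 3 `ClCc1ccc(Cn2cnc3nc(Cl)nc(Cl)c32)cc1`, which carries two chloro groups on the core, gives 28800 nM in this assay; the two values of compound 2 and compound 3 differ by more than the scatter, though no direct step connects them. Compound 4 `ClCc1ccc(Cn2cnc3c(Cl)nc(Cl)nc32)cc1` is not yet measured; it differs from compound 1 by chloro in place of hydrogen on an aromatic carbon. Among the measured compounds shown here, with no number for compound 1, no step can be sized, and the direction is open. Compound 4 is estimated at 10000 nM, expected within 3000 nM to 40000 nM.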

Compound 4, concentration for total growth inhibition: 17400 nM
For compound 4 the middle estimate is 1.7-fold (0.24 log units) below the measured one, within the range that was stated.
By their numbers in this assay, from the lowest: compound 2; then compounds 4 and 3 (each within the scatter of the next).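

No new step can be read between compound 1 and compound 4. On these data alone, what chloro in place of hydrogen on the shared core does in this assay stays open. No evidence on the cause is available.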